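Growth Inhibition Notes: Ethyl to Isopropyl in the Series

The source may hold more compounds than are shown below. What is called first, only, known or untested is meant among the compounds shown, and "the series" means these compounds.

- compound 1 `CC(C)c1nc2cc(Cl)c(Cl)cc2[nH]1`: 57000 nM
- compound 2 `CCc1nc2cc(Cl)c(Cl)cc2n1C1CCCC1`: 52000 nM

Both values come from a functional assay on MCF7 cells (Homo sapiens) for cytotoxicity, read by MTT assay, with a stated time of 48 h; on this read-out lower numbers stand for stronger inhibition of growth and higher numbers for weaker inhibition of growth. Compound 2 at 52000 nM lies within the scatter of compound 1 at 57000 nM, although the two structures differ in more than one place.

Compound 3 `CC(C)c1nc2cc(Cl)c(Cl)cc2n1C1CCCC1` arises from compound 2 through one change: methyl in place of hydrogen on a saturated chain carbon bound to an aromatic carbon and a saturated chain carbon, which reads as ethyl to isopropyl. Among the compounds with values here, no measured pair shows this change alone. Compound 1, which also carries isopropyl, gives 57000 nM, so no step beyond the scatter is expected in this assay. The expected step is small, a 1.2-fold lower number from compound 2 to compound 3 (0.06 log units; within the scatter). For compound 3 the estimated value is 45000 nM, with an expected range of 22000 nM to 90000 nM.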

Compound 3, concentration for 50% growth inhibition: 43000 nM
Beside the measured number, compound 3's estimate is 1.0-fold (0.02 log units) above it; measured number inside the range.
By their numbers in this assay, from the lowest: compounds 3, 2 and 1 (each within the scatter of the next).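

In this assay, within the data shown here, ethyl to isopropyl with the cyclopentyl group held in place gives a 1.2-fold lower number from compound 2 to compound 3 (0.08 log units; within the scatter) and so provides the first direct reading of this change on a saturated chain carbon bound to an aromatic carbon and a saturated chain carbon. Among these compounds, with isopropyl held in place, cyclopentyl in place of hydrogen on an aromatic nitrogen gives a 1.3-fold lower number from compound 1 to compound 3 (0.12 log units; within the scatter) and so provides the first direct reading of that change as well; neither single change separates the compounds on this read-out. Nothing measured on these compounds offers an explanation for either step.

The compounds shown leave open whether any group at either place can produce a step beyond the scatter. A longer chain or an amine on the saturated chain carbon, or a carboxylic acid-bearing chain on the aromatic nitrogen, would be the next readings to compare.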